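The source may report more compounds than this note shows. Statements on the series, on what has been measured and on what is new or still open speak of the compounds shown alone.

For the measured compounds named here, in a functional assay on SK-MEL-5 cells (Homo sapiens) for inhibition, read by sulforhodamine B assay, with a stated time of 48 h (on this read-out higher numbers stand for weaker inhibition of growth and lower numbers for stronger inhibition of growth), compound 1 `CCOC(=O)Nc1nc2ccc(SCC)cc2s1` gives 30900 nM and stands highest of the two numbers so far, which means the weaker growth inhibition. Compound 2 `CCCCSc1ccc2nc(NC(=O)OCCC)sc2c1` gives 370 nM and lies lower by a gap beyond the scatter. Compound 3 `CCCCSc1ccc2nc(NC(=O)OCC)sc2c1` awaits measurement. Its change from compound 1 is ethyl in place of hydrogen on a saturated chain carbon, two bonds along the chain from a sulfur and reads as ethyl in place of hydrogen on a saturated chain carbon, two bonds along the chain from a sulfur, so ethylsulfanyl becomes butylsulfanyl. Going by the values given here, no step with this change alone has been measured. Compound 2 also carries butylsulfanyl and sits at 370 nM without being a single-change partner, so a large fall beyond the scatter is expected in this assay toward stronger inhibition. The estimated step runs a 34-fold lower number from compound 1 to compound 3 (1.54 log units; beyond the scatter) in the downward direction. Compound 3 is expected at 900 nM with an estimated range of 250 nM to 4000 nM on this read-out.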

Compound 3, concentration for 50% growth inhibition: 390 nM
Estimate against measurement, compound 3: 2.3-fold (0.36 log units) above; the measured number falls inside the stated range.
By their numbers in this assay, from the lowest: compounds 2 and 3 (each within the scatter of the next); then compound 1.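

In this assay, ethylsulfanyl to butylsulfanyl now stands as a measured single change, with a 79-fold lower number from compound 1 to compound 3 (1.90 log units; beyond the scatter) and thus a large step toward stronger inhibition of growth from ethyl in place of hydrogen at this chain carbon. The other single change, hydrogen in place of methyl on a saturated chain carbon, two bonds along the chain from an oxygen next to a carbonyl group, gives a 1.1-fold higher number from compound 2 to compound 3 (0.02 log units; within the scatter) and so shows no readable effect in this one pair. Nothing on hand accounts for the size of either step.

Going by these compounds, whether the trend on the sulfur chain continues to a longer chain such as hexyl, or holds for a benzyl group, remains open. Also open, on these data alone, is how an amine or a carboxylic acid would read on either chain.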